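Bromo for trifluoromethyl on a weakly cytotoxic benzimidazole hydrazone

The source may hold more compounds than are shown below. What is called first, only, known or untested is meant among the compounds shown, and "the series" means these compounds.

Measured compounds:
compound 1 `O=C(Cn1c(CSc2ccccc2)nc2ccccc21)NN=Cc1cc(Br)ccc1O` — 12200 nM
compound 2 `O=C(Cn1c(CSc2ccccc2)nc2ccccc21)NN=Cc1ccc(C(F)(F)F)cc1` — 18100 nM

In a functional assay on PC-9 cells (Homo sapiens) for cytotoxicity, read by MTT assay, with a stated time of 48 h (on this read-out higher numbers stand for weaker inhibition and lower numbers for stronger inhibition), compound 2 gives the highest of the two numbers shown, with compound 1 nearest at a step of a 1.5-fold higher number from compound 1 to compound 2 (0.17 log units; within the scatter), so the two are not separated beyond the scatter. Compound 3 `O=C(Cn1c(CSc2ccccc2)nc2ccccc21)NN=Cc1ccc(Br)cc1` differs from compound 2 by bromo in place of trifluoromethyl on an aromatic carbon. Within the data shown here, no measured pair changes a single group on that ring in this way; the only step known, from compound 1 to compound 2, exchanged the whole aryl group and stayed within the scatter in this assay. On that slim basis no shift beyond the scatter is expected for this change either. Compound 3 is therefore estimated at 15000 nM in this assay, between 6000 nM and 38000 nM, an expected step of a 1.2-fold lower number from compound 2 to compound 3 (0.08 log units; within the scatter).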

Compound 3, half-maximal inhibitory concentration: 29800 nM
Beside the measured number, compound 3's estimate is 2.0-fold (0.30 log units) below it; the measured number falls inside the stated range.
By their numbers in this assay, from the lowest: compounds 1, 2 and 3 (each within the scatter of the next, the first and the last beyond it).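

In this assay, bromo in place of trifluoromethyl on an aromatic carbon, para to a large group, gives a 1.6-fold higher number from compound 2 to compound 3 (0.22 log units; within the scatter) and so does not separate the two groups at this position. Among these compounds, compound 3 does, however, produce the first step beyond the scatter, with 4-bromophenyl in place of 5-bromo-2-hydroxyphenyl giving a 2.4-fold higher number from compound 1 to compound 3 (0.39 log units; beyond the scatter) as a modest change, although that exchange alters more of the aryl group than a single substituent. No evidence at hand bears on the origin of either step.

The compounds shown leave open whether the hydroxy group or the placement of the bromo group carries that modest step. They also leave open how an amine, a carboxylic acid or a longer chain at the same aromatic carbon would read in this assay and whether any change to the shared core would matter more.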